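The source may hold more compounds than are shown below. What is called first, only, known or untested is meant among the compounds shown, and "the series" means these compounds.

Among the compounds with values here, in an ADME assay on CHO cells (Cricetulus griseus) for cytotoxicity (on this read-out higher numbers stand for weaker inhibition and lower numbers for stronger inhibition), compound 1 (`Cc1nnc(/C(=N\O)c2nc3ccccc3s2)o1`) is reported as "not determined" (no result reported) while compound 2 (`Cc1nnc(/C(=N\O)c2nc3ccccc3s2)s1`) gives 38000 nM as the only number so far, so compound 2 has no rank yet. Compound 3 (`O/N=C(\c1ccccc1)c1nc2ccccc2s1`) carries phenyl in place of 5-methyl-1,3,4-thiadiazol-2-yl on a carbon with a double bond to nitrogen. Within the data shown here, the data so far hold no step that guides this change in this assay. Only a modest move toward stronger inhibition is expected (a 1.9-fold lower number from compound 2 to compound 3 (0.28 log units; within the scatter)). For compound 3 the estimated value is 20000 nM within an expected range (7000 nM to 60000 nM).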

Compound 3, half-maximal inhibitory concentration: > 100000 nM
Compound 3 gave a limit, no number (the forecaster's own chance of this, stated with the estimate: 15%); at least 5.0-fold (0.69 log units) between middle value and limit.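

Within the data shown here, on a carbon with a double bond to nitrogen, phenyl in place of 5-methyl-1,3,4-thiadiazol-2-yl gives the first readable step in this assay, toward weaker inhibition: an at least 2.6-fold higher number from compound 2 to compound 3 (0.42 log units; beyond the scatter). Compound 3 gives > 100000 nM, which is a limit of the assay and not a number. The step therefore fixes a direction, while its full size stays unknown: the limit of > 100000 nM in this assay, at which 1 of the 3 values shown sits.

From the compounds shown here alone, it remains open whether the methyl or the ring hetero atoms of 5-methyl-1,3,4-thiadiazol-2-yl carry this difference. Also open, going by these compounds, is whether an amine or a carboxylic acid on the phenyl of compound 3 would move the number back toward stronger inhibition.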